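The source may hold more compounds than are shown below. What is called first, only, known or untested is meant among the compounds shown, and "the series" means these compounds.

This account follows a set of compounds built on a shared core, beginning with compound 1 `COc1cc(Cc2cnc(/N=C3\C(=O)N(CN4CCC(C)CC4)c4ccc(Cl)cc43)nc2N)cc(OC)c1OC`, which in an ADME assay on CCRF-CEM cells (Homo sapiens) for cytotoxicity, read by MTT assay, with a stated time of 5 days (on this read-out lower numbers stand for higher toxicity in this test and higher numbers for lower toxicity in this test), gives 46.3 ug/mL. Compound 2 `CCCCN(CCCC)CN1C(=O)/C(=N\c2ncc(Cc3cc(OC)c(OC)c(OC)c3)c(N)n2)c2cc(Cl)ccc21` belongs to the same series, but in this assay compound 2 gives "not determined" (no result reported), so there is no number on which it can be placed against compound 1. The next compound, compound 3 `COc1cc(Cc2cnc(/N=C3\C(=O)N(CN4CCN(C)CC4)c4ccc(Cl)cc43)nc2N)cc(OC)c1OC`, differs from compound 2 in one place: 4-methylpiperazin-1-yl in place of dibutylamino on a saturated chain carbon bound to an amide-type nitrogen in a ring. Among the compounds with values here, no measured step links compound 2 and compound 3 in this assay, and the only reference available is compound 1, whose ring group on the same chain carbon resembles the one entering in compound 3. Any step from compound 2 cannot be sized here; the outcome for compound 3 is therefore expected to sit near the value of compound 1 rather than to move in a known direction. On that basis compound 3 is estimated to give 40 ug/mL in this assay, within a range from 15 ug/mL to 110 ug/mL.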

Compound 3, half-maximal cytotoxic concentration: 88 ug/mL
For compound 3 the middle estimate is 2.2-fold (0.34 log units) below the measured one, within the range that was stated.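

In this assay there is a 1.9-fold higher number from compound 1 to compound 3 (0.28 log units; within the scatter) when 4-methylpiperazin-1-yl stands in place of 4-methylpiperidin-1-yl on a saturated chain carbon bound to an amide-type nitrogen in a ring. Within the data shown here, this is the first measured comparison at this position, and it shows that exchanging these two ring groups leaves compound 1 and compound 3 indistinguishable in this test, while the step from compound 2 to compound 3 cannot be read. No supporting information bears on this result.

Going by these compounds, how dibutylamino compares with either ring group at this position remains open. So does whether a morpholin-4-yl ring or a smaller open-chain amine such as dimethylamino on the same chain carbon would also leave the read-out within the scatter of compound 1.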